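Moving a double bond: allyl to prop-1-en-1-yl

This account rests on a few compounds, and the source may have more. Where it says the series, first, only, none or still open, it means among the compounds named here.

Measured so far:
- compound 1, `C=CCc1cc(OC)c(O[C@H](C)[C@H](OC(C)=O)c2cc(OC)c(OC)c(OC)c2)c(OC)c1`: 85000 nM
- compound 2, `COc1ccc([C@@H](O)[C@@H](C)Oc2ccc([C@H]3O[C@H](c4ccc(OC)c(OC)c4)[C@H](C)[C@H]3C)cc2OC)cc1OC`: 110000 nM
- compound 3, `COc1cc(C(=O)[C@@H](C)Oc2c(OC)cc(/C=C/CO)cc2OC)cc(OC)c1OC`: > 200000 nM

These three compounds were tested in an ADME assay on P3HR-1 cells (Homo sapiens) for cytotoxicity, read by microscopy and trypan blue exclusion, with a stated time of 2 days; a higher number here means that more compound is tolerated, a lower number that less compound is tolerated. In this assay compound 1 gives 85000 nM. Compound 2 gives 110000 nM, and the two numbers sit within the usual scatter of each other, so compound 1 stands close beside compound 2. For compound 3 the result is only a limit, > 200000 nM, not a number, as the limit of > 200000 nM in this assay, at which 1 of the 3 values shown sits, notes.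

Compound 4, `C/C=C/c1cc(OC)c(O[C@H](C)[C@H](OC(C)=O)c2cc(OC)c(OC)c(OC)c2)c(OC)c1`, has not yet been measured in this assay. It is built from the same atoms as compound 1, joined differently: prop-1-en-1-yl in place of allyl on an aromatic carbon. For the measured compounds named here, no pair of measured compounds differs in a single place, so there is no measured step to lean on. Given how small this rearrangement is, the step from compound 1 to compound 4 is expected to stay within the scatter, in no particular direction. Compound 4 is therefore expected to give about 90000 nM in this assay, somewhere between 40000 nM and 200000 nM. That amounts to an expected 1.1-fold higher number from compound 1 to compound 4 (0.02 log units; within the scatter).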

Compound 4, half-maximal cytotoxic concentration: 76800 nM
Estimate against measurement, compound 4: 1.2-fold (0.07 log units) above; measured number inside the range.
By their numbers in this assay, from the lowest: compounds 4, 1 and 2 (each within the scatter of the next). At a limit, above all of these: compound 3.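

In this assay, prop-1-en-1-yl in place of allyl on this aromatic carbon gives a 1.1-fold lower number from compound 1 to compound 4 (0.04 log units; within the scatter). For the compounds shown here, this is the first step in the set that changes a single place, and it shows that at this position, meta to two methoxy groups, moving the double bond along the chain leaves compound 4 indistinguishable from compound 1. Nothing measured here speaks to why the two compounds read alike.

This one rearrangement keeps the same atoms, so it cannot say whether a different group on this aromatic carbon, such as a longer chain, an amine or a carboxylic acid, would leave the number in place. Compound 3 gives > 200000 nM, which is a limit and not a number, and it differs from compound 4 in more than one place, so it settles nothing here.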